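The source may hold more compounds than are shown below. What is called first, only, known or untested is meant among the compounds shown, and "the series" means these compounds.

Measured so far in an ADME assay on the whole organism (Rattus norvegicus, strain Sprague-Dawley) for pharmacokinetics, read by LC-MS, at a dose of 1 mg/kg by the intravenous route (on this read-out higher numbers stand for fast clearance and lower numbers for slow clearance), are two compounds.

- Compound 1 (`Cc1nc(C)c([C@H](OC(C)(C)C)C(=O)O)c(N2CCC(C)(C)CC2)c1-c1ccc2c(c1)CCN(Cc1cccc(F)c1F)C2`) gives 8.1 mL/min/kg in this read-out
- Compound 2 (`Cc1nc(C)c([C@H](OC(C)(C)C)C(=O)O)c(N2CCC(C)(C)CC2)c1-c1ccc2c(c1)CCN(Cc1ccc(F)cc1F)C2`) gives 20.1 mL/min/kg in this read-out

Compound 2 holds the higher of the two numbers, and the gap to compound 1 lies beyond the scatter. The next compound is compound 3 (`Cc1nc(C)c([C@H](OC(C)(C)C)C(=O)O)c(N2CCC(C)(C)CC2)c1-c1ccc2c(c1)CCN(c1nc3cnccc3s1)C2`), and it differs from compound 2 on an amine nitrogen in a ring (a group of 9 heavy atoms (6 carbon, 2 nitrogen, 1 sulfur; one five-membered aromatic ring with 2 hetero atoms, one six-membered aromatic ring with 1 hetero atom) in place of a group of 9 heavy atoms (7 carbon, 2 fluorine; one six-membered aromatic ring of carbon only), on an amine nitrogen in a ring). The 2,4-difluorobenzyl group leaves entirely, and no ring of it remains.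

For the measured compounds named here, only one measured step bears on this change, a 2.5-fold higher number from compound 1 to compound 2 (0.39 log units; beyond the scatter), which is modest but beyond the scatter. It involves the same group on the same nitrogen, yet it is a much smaller edit than the one made here. It therefore gives a rough scale and no firm direction. The value of compound 1 at 8.1 mL/min/kg shows that a lower number is reachable with a change at this place, so a step of similar or smaller size is expected, leaning downward. The estimate amounts to a 1.5-fold lower number from compound 2 to compound 3 (0.19 log units; within the scatter) as the expected step. Compound 3 is expected near 13 mL/min/kg in this assay, with an estimated range from 4.5 mL/min/kg to 36 mL/min/kg as its upper end.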

Compound 3, clearance: 14.8 mL/min/kg
Beside the measured number, compound 3's estimate is 1.1-fold (0.06 log units) below it, within the range that was stated.
By their numbers in this assay, from the lowest: compounds 1, 3 and 2 (each within the scatter of the next, the first and the last beyond it).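

In this assay, removing the 2,4-difluorobenzyl group altogether and placing a group with a five-membered and a six-membered aromatic ring, nitrogen, sulfur and 3 hydrogen-bond acceptors on the same amine nitrogen gives a 1.4-fold lower number from compound 2 to compound 3 (0.13 log units; within the scatter), so even this complete exchange of the group produces no step beyond the scatter. The new compound also cannot be separated from the 2,3-difluorobenzyl compound, with a 1.8-fold higher number from compound 1 to compound 3 (0.26 log units; within the scatter), although the two difluorobenzyl compounds themselves differ beyond the scatter, with a 2.5-fold higher number from compound 1 to compound 2 (0.39 log units; beyond the scatter); the position therefore accepts a carbon-only benzyl group and a directly attached hetero-aromatic group with clearance values that overlap, and the new compound sits in the middle without being distinguishable from either end. Nothing available here accounts for these clearance values.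

From the compounds shown here alone, it remains open which atoms of the entering group matter for clearance, since its ring nitrogen and sulfur changed together with the loss of the benzyl carbon chain and the fluorines. Also open, going by these compounds, is where an unsubstituted benzyl group or a single pyridine ring on this amine nitrogen would fall in this assay.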